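The compounds below may be only part of what the source reports. "The series", "measured", "known", "first", "only" and "open" are said of these compounds alone.

Compound 1 `CCC/C=C/C(=O)Nc1cccc(Oc2nc(Nc3ccn(C)n3)nc3c2CSCC3)c1` and compound 3 `CCC/C=C/C(=O)Nc1cccc(Oc2nc(Nc3cccc(C#N)c3)nc3c2CSCC3)c1` share a core and differ where 3-cyanophenyl in place of 1-methyl-1H-pyrazol-3-yl on a nitrogen on an aromatic ring describes; in a functional assay on MCF7 cells (Homo sapiens) for antiproliferative activity, read by MTT assay, with a stated time of 72 h (on this read-out higher numbers stand for weaker inhibition and lower numbers for stronger inhibition), compound 1 gives 22600 nM, and compound 3 gives 15300 nM, so that a 1.5-fold lower number from compound 1 to compound 3 (0.17 log units; within the scatter). Compound 2 `CC(C)=CC(=O)Nc1cccc(Oc2nc(Nc3ccn(C)n3)nc3c2CSCC3)c1` carries the change 2-methylprop-1-en-1-yl in place of pent-1-en-1-yl on a carbonyl carbon relative to compound 1. In this assay compound 2 reaches only a limit, > 50000 nM. That limit is recorded as the limit of > 50000 nM in this assay, at which 1 of the 3 values shown sits, and it means an at least 2.2-fold higher number from compound 1 to compound 2 (0.34 log units; beyond the scatter). Compound 4 `CC(C)=CC(=O)Nc1cccc(Oc2nc(Nc3cccc(C#N)c3)nc3c2CSCC3)c1` is not yet measured in this assay; it stands to compound 3 as compound 2 stands to compound 1, the same change (2-methylprop-1-en-1-yl in place of pent-1-en-1-yl on a carbonyl carbon), made at a place described in the same words, so the two occurrences count as the same change. For compound 4 the step from compound 3 is expected to be a 2.9-fold higher number from compound 3 to compound 4 (0.47 log units; beyond the scatter), an estimate that rests on the step already seen from compound 1 to compound 2 in this assay, an at least 2.2-fold higher number from compound 1 to compound 2 (0.34 log units; beyond the scatter), and on the limit at which that step ended. Compound 4 is therefore estimated at 45000 nM, with the range from 25000 nM to 90000 nM, and a real chance that this assay again reports only a limit.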

Compound 4, half-maximal inhibitory concentration: > 50000 nM
Compound 4 was reported as a limit; the forecaster's own chance of this, stated with the estimate: 45%; middle value at least 1.1-fold (0.04 log units) from the limit.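

In this assay, the change from pent-1-en-1-yl to 2-methylprop-1-en-1-yl on a carbonyl carbon carries over to the second core in the same direction, with an at least 3.2-fold higher number from compound 3 to compound 4 (0.51 log units; beyond the scatter). Compound 4 is reported only as a limit of the assay, > 50000 nM, and not as a number. The two cores therefore agree on direction but not demonstrably on size, and the step between the two limit compounds, compound 2 and compound 4, cannot be read: the same change on two cores in this assay, an at least 2.2-fold higher number (0.34 log units; beyond the scatter) from compound 1 to compound 2 and an at least 3.2-fold higher number (0.51 log units; beyond the scatter) from compound 3 to compound 4; the limit leaves it open whether they differ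

The compounds shown leave open how activity responds to other groups on this carbonyl carbon, such as a longer chain, a cyclopropyl ring or a chain carrying an amine, and whether any of these would give lower numbers than pent-1-en-1-yl on either core. They also leave the true values of the two limit compounds unresolved: the limit of > 50000 nM in this assay, at which 2 of the 4 values shown sit.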